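The source may hold more compounds than are shown below. What is called first, only, known or untested is meant among the compounds shown, and "the series" means these compounds.

Compound 1, `CC1CC1C(=O)N1CCc2nc(C#Cc3ccccc3)sc2C1`, gives in an assay on HEK293 cells for negative allosteric modulation of metabotropic glutamate receptor 5 (Homo sapiens), read by FLIPR, with a stated time of 1 h (a higher number here means a weaker inhibitor, a lower number a stronger inhibitor), the value > 10000 nM, which is a limit of the assay and not a number.
Compound 2, `O=C(C1CC12CCC2)N1CCc2nc(C#Cc3ccccc3)sc2C1`, gives in this assay the value > 10000 nM, again a limit.
Compound 3, `O=C(N1CCCCC1)N1CCc2nc(C#Cc3ccccc3)sc2C1`, gives in this assay the value > 10000 nM, also a limit.

Among the compounds with values here, compound 3 therefore stands at the limit of > 10000 nM in this assay, at which 3 of the 3 values shown sit, and every measured compound sits at that same limit; no compound here has a number of its own. The three compounds differ only in the group attached to the carbonyl carbon, and the steps between them, a step that the two limits leave unreadable from compound 1 to compound 2, a step that the two limits leave unreadable from compound 1 to compound 3 and a step that the two limits leave unreadable from compound 2 to compound 3, cannot be read in size or direction, because each end is a limit.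

Compound 4, `O=C(N1CCC(F)CC1)N1CCc2nc(C#Cc3ccccc3)sc2C1`, is reached from compound 3 by the change (fluoro in place of hydrogen on a saturated ring carbon). This is a small change on the same group on the carbonyl carbon that was varied among compounds 1, 2 and 3 without any of them leaving the limit. Within the data shown here, none of the measured steps gives a readable size, so no direction can be taken from them. The expectation for the step that the limit leaves unreadable from compound 3 to compound 4 is that compound 4 stays at the limit as well. The estimate for compound 4 in this assay is 15000 nM, expected to lie between 5000 nM and 50000 nM.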

Compound 4, half-maximal inhibitory concentration: > 10000 nM
Compound 4: only a limit was reported; the forecaster's own chance of this, stated with the estimate: 80%; the middle value is on the limit's open side.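

In this assay compound 4 gives > 10000 nM, a limit of the assay and not a number. Within the data shown here, no step from compound 1, compound 2 or compound 3 to compound 4 can be read, because all four compounds sit at one limit: the limit of > 10000 nM in this assay, at which 4 of the 4 values shown sit. The compounds shown leave open whether any group on the carbonyl carbon changes inhibition at all.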